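Notes on two thiazole ethers and a methoxyphenyl analogue

The compounds below may be only part of what the source reports. "The series", "measured", "known", "first", "only" and "open" are said of these compounds alone.

Measured so far:
compound 1 `O=C(O)CC1COc2cc(OCc3csc(-c4ccccc4)n3)ccc21` — 0.15%
compound 2 `Cc1nc(-c2cc3ccccc3o2)sc1COc1ccc2c(c1)OCC2CC(=O)O` — 14.8%

In a functional assay on CHO cells for agonist activity at Free fatty acid receptor 1 (Homo sapiens), read by FLIPR and calcium flux, tested at 100 nM (on this read-out higher numbers stand for a stronger effect at the one concentration tested and lower numbers for a weaker effect), compound 2 holds the highest of the two numbers; compound 1 gives 0.15%, a value lower by more than the usual scatter. Compound 3 `COc1ccc(-c2nc(C)c(COc3ccc4c(c3)OCC4CC(=O)O)s2)cc1` differs from compound 2 by 4-methoxyphenyl in place of 1-benzofuran-2-yl on an aromatic carbon. Going by the values given here, no step between two measured compounds is available for this change, so the expectation rests on the two values alone. The step of a number 7.8 percentage points lower from compound 2 to compound 3 (within the scatter) is expected to run downward, of a size that may or may not exceed the scatter. Compound 3 is estimated at 7%, with a range from 0% to 18%.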

Compound 3, a percentage reported as activity, at one concentration (the size of the read-out at that concentration, not a potency): 46.8%
Compound 3: the middle estimate sits 39.8 percentage points below what was measured, outside the stated range (above it).
By their numbers in this assay, from the lowest: compound 1; then compound 2; then compound 3.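

In this assay, going by these compounds alone, 4-methoxyphenyl in place of 1-benzofuran-2-yl on this aromatic carbon, next to the ring nitrogen and next to the ring sulfur, gives a number 32 percentage points higher from compound 2 to compound 3 (beyond the scatter) and is the first one-place comparison. The read-out at this position therefore depends on the group it carries, although this is a size at one concentration and not a potency. No measurement shown accounts for the step.

On these data alone, it remains open whether the methoxy group itself matters, or whether a 4-chlorophenyl or 4-ethoxyphenyl group on the same carbon would give a similar read-out. As far as these compounds go, whether the step holds across a concentration range also remains open.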